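Changing the Aryl Group on a Sulfonamide Nitrogen

The source may hold more compounds than are shown below. What is called first, only, known or untested is meant among the compounds shown, and "the series" means these compounds.

In a physicochemical assay for lipophilicity, at pH 7.4 (on this read-out higher numbers stand for higher lipophilicity and lower numbers for lower lipophilicity), compound 1 `CCc1ccc(N(CC(C)C)S(=O)(=O)c2ccc3c(c2)C(O)CC(C2CCOCC2)O3)cc1` gives 4.12 and compound 2 `CC(C)CN(c1ccccc1C(F)(F)F)S(=O)(=O)c1ccc2c(c1)C(O)CC(C1CCOCC1)O2` gives 4.14, so compound 2 stands level with compound 1 within the scatter. Compound 3 `CC(C)CN(c1ccc(F)cc1F)S(=O)(=O)c1ccc2c(c1)C(O)CC(C1CCOCC1)O2` has 2,4-difluorophenyl in place of 2-(trifluoromethyl)phenyl on a sulfonamide nitrogen. Among the measured compounds shown here, only one measured step bears on this, another swap at that nitrogen: a number 0.02 log units higher from compound 1 to compound 2 (within the scatter). It is tiny, but it is a single case and a different swap. The expected change is therefore small, leaning lower and staying within the scatter: a number 0.24 log units lower from compound 2 to compound 3 (within the scatter). For compound 3 the estimated value is 3.9, with an expected range from 3.5 to 4.3.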

Compound 3, distribution coefficient: 3.53
Compound 3: the middle estimate sits 0.37 log units above what was measured; low and high end bracket the measured number.
By their numbers in this assay, from the lowest: compound 3; then compounds 1 and 2 (each within the scatter of the next).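

The aryl group on this sulfonamide nitrogen can shift the number after all. In this assay, 2,4-difluorophenyl gives a number 0.61 log units lower from compound 2 to compound 3 (beyond the scatter), and likewise a number 0.59 log units lower from compound 1 to compound 3 (beyond the scatter). Among the compounds shown here, this is the first swap here with a step beyond the scatter, since the two earlier aryl groups stood level, and no measurement at hand explains it. Still open, going by these compounds, is whether both fluorines are needed for this step, as a single fluorine on the phenyl ring would show. Also open, on these data alone, is what an aryl group carrying an amine or a carboxylic acid would give at this nitrogen.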